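The compounds below may be only part of what the source reports. "The series", "measured", "known", "first", "only" and "open" are said of these compounds alone.

Four compounds are compared here, all tested for their ability to reduce swelling in a rat paw. Compound 1, `C/C(=N\OCC(=O)O)c1ccc(N(C)C)cc1`, carries a dimethylamino group on an aromatic carbon. In a functional assay on the whole organism for inhibition, with Rattus norvegicus as the target, read by paw edema, with stated times of 1 h and 3 h, at a dose of 50 mg/kg by the oral route (on this read-out lower numbers stand for less inhibition and higher numbers for more inhibition at the one dose given (going by the name of the read-out)), compound 1 reaches only a limit of the assay, < 20%. Compound 2, `C/C(=N\OCC(=O)O)c1ccc([N+](=O)[O-])cc1`, arises from compound 1 by nitro in place of dimethylamino on an aromatic carbon. In this assay compound 2 also stops at a limit, < 20%. The step that the two limits leave unreadable from compound 1 to compound 2 therefore cannot be sized. Compound 3, `CN(C)c1ccc(/C=N/OCC(=O)O)cc1`, rests on a second core; how the two cores differ is not broken down here. In this assay compound 3 likewise gives only a limit, < 20%. The shared picture is the limit of < 20% in this assay, at which 3 of the 3 values shown sit, so none of the three measured compounds shows a readable effect at the dose given.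

Compound 4, `O=C(O)CO/N=C/c1ccc([N+](=O)[O-])cc1`, is not yet measured; it arises from compound 3 by nitro in place of dimethylamino on an aromatic carbon. This is the same kind of change as that from compound 1 to compound 2, though the place differs: in compound 3 the aromatic carbon lies para to a group of 7 heavy atoms, in compound 1 para to a group of 8 heavy atoms. Because the limit of < 20% in this assay, at which 3 of the 3 values shown sit, covers every measured compound, the step from compound 3 to compound 4 in this assay is expected to be a step that the limit leaves unreadable from compound 3 to compound 4. Compound 4 is accordingly estimated at 12%, most likely between 0% and 28%.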

Compound 4, a percentage reported as inhibition, in the whole organism at one dose (the size of the read-out at that dose, not a potency): < 20%
Compound 4: only a limit was reported; the forecaster's own chance of this, stated with the estimate: 80%; the middle value does not contradict the limit.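

In this assay compound 4 also stops at a limit of the assay, < 20%. With compound 3 at a limit as well, no size can be read for the change from compound 3 to compound 4, and the shared picture stays as it was: the limit of < 20% in this assay, at which 4 of the 4 values shown sit.

The compounds shown leave open whether nitro in place of dimethylamino changes the inhibition at all, and how the four compounds would rank on readable values.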